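Bromo-Alkene Sulfonamides: Swapping a Chain for a Ring

The source may report more compounds than this note shows. Statements on the series, on what has been measured and on what is new or still open speak of the compounds shown alone.

Of the compounds shown here, two of a shared core have been measured in a functional assay on SW1573 cells (Homo sapiens) for antiproliferative activity, read by sulforhodamine B assay, with a stated time of 48 h; a higher number here means a weaker inhibitor of growth, a lower number a stronger inhibitor of growth. Compound 1, `Cc1ccc(S(=O)(=O)N2CCC(Cl)=CC2C2CCCCC2)cc1`, gives 62000 nM in this assay. Compound 2, `CCCCCCCC1C=C(Br)CCN1S(=O)(=O)c1ccc(C)cc1`, gives 49000 nM in this assay. These two numbers lie within the scatter of each other, so neither compound can be called the stronger grower-inhibitor on this evidence; both are weak.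

Compound 3, `Cc1ccc(S(=O)(=O)N2CCC(Br)=CC2C2CCCCC2)cc1`, is yet to be measured in this assay. It differs from compound 2 by cyclohexyl in place of heptyl on a saturated ring carbon. Among the measured compounds shown here, no measured pair shows this exact change, so the size of the step is not known from the data. Because compound 1, which also carries cyclohexyl, gives 62000 nM, no step beyond the scatter is expected. Compound 3 is therefore estimated at 55000 nM, in a range from 25000 nM to 120000 nM, which would mean a step of a 1.1-fold higher number from compound 2 to compound 3 (0.05 log units; within the scatter).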

Compound 3, concentration for 50% growth inhibition: 65000 nM
Estimate against measurement, compound 3: 1.2-fold (0.07 log units) below, within the range that was stated.
By their numbers in this assay, from the lowest: compounds 2, 1 and 3 (each within the scatter of the next).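

In this pair, cyclohexyl in place of heptyl on a saturated ring carbon, next to the ring nitrogen, gives a 1.3-fold higher number from compound 2 to compound 3 (0.12 log units; within the scatter) in this assay and so shows that a six-membered carbon ring and a heptyl chain cannot be told apart at this position. Bromo in place of chloro on a double-bonded ring carbon gives a 1.0-fold higher number from compound 1 to compound 3 (0.02 log units; within the scatter) in this assay and shows that these two halogens cannot be told apart either when cyclohexyl is present. No measurement offered here explains either result.

From the compounds shown here alone, it remains open whether methyl, or a chain ending in an amine or a carboxylic acid, on that saturated ring carbon would give a step beyond the scatter. Going by these compounds, the effect of hydrogen or a nitrile in place of the halogen also remains open.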